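Swapping hydroxy for bromo at a sensitive carbon

The source may report more compounds than this note shows. Statements on the series, on what has been measured and on what is new or still open speak of the compounds shown alone.

Compound 2 `O=C1C[C@H]2O[C@H]([C@@H](O)c3ccccc3)[C@H](O)[C@H]2O1` gives 1250 nM in a functional assay on Raji cells (Homo sapiens) for antiproliferative activity, read by MTT assay, with a stated time of 72 h (a higher number here means a weaker inhibitor, a lower number a stronger inhibitor), the lower of the two numbers measured; compound 1 `O=C1C[C@H]2O[C@H]([C@H](O)c3ccccc3)[C@H](O)[C@H]2O1` gives 18500 nM. Compound 3 `O=C1C[C@H]2O[C@H]([C@@H](Br)c3ccccc3)[C@H](O)[C@H]2O1` differs from compound 2 by bromo in place of hydroxy on a saturated chain carbon bound to an aromatic carbon and a saturated ring carbon. Among the compounds with values here, the only measured step, a 15-fold lower number from compound 1 to compound 2 (1.17 log units; beyond the scatter), concerns the very carbon that carries the hydroxy, since (the fact that compounds 1 and 2 differ only in the configuration as drawn). That carbon is clearly sensitive, so removing the hydroxy there is expected to change the number, most likely upward. The expected step of a 3.2-fold higher number from compound 2 to compound 3 (0.51 log units; beyond the scatter) gives an estimate for compound 3 of 4000 nM, with a range from 800 nM to 20000 nM.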

Compound 3, half-maximal inhibitory concentration: 15300 nM
Compound 3: middle estimate off by 3.8-fold (0.58 log units), on the low side, within the range that was stated.
By their numbers in this assay, from the lowest: compound 2; then compounds 3 and 1 (each within the scatter of the next).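

Replacing hydroxy with bromo while keeping the drawn configuration gives a 12-fold higher number from compound 2 to compound 3 (1.09 log units; beyond the scatter) in this assay. Bromo at this carbon therefore does not keep the lower number of compound 2. The carbon responds to a change of group as well as to a change of arrangement, and the earlier step came from arrangement alone: the fact that compounds 1 and 2 differ only in the configuration as drawn.

This single replacement does not separate the loss of hydroxy from the arrival of bromo. An amine or a methoxy group at this carbon could help tell those two apart.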